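The source may report more compounds than this note shows. Statements on the series, on what has been measured and on what is new or still open speak of the compounds shown alone.

Measured so far in a functional assay on ASPC1 cells (Homo sapiens) for inhibition, read by MTT assay, with a stated time of 72 h; a higher number here means a weaker inhibitor of growth, a lower number a stronger inhibitor of growth:
compound 1 `O=S(=O)(NCCCNCc1ccc(C(F)(F)F)cc1)c1cc(C(F)(F)F)cc(C(F)(F)F)c1`, 2000 nM;
compound 2 `O=S(=O)(NCCCNCc1ccc(-c2ccccc2)cc1)c1cc(C(F)(F)F)cc(C(F)(F)F)c1`, 2500 nM;
compound 3 `CC(C)(C)c1ccc(CNCCNS(=O)(=O)c2cc(C(F)(F)F)cc(C(F)(F)F)c2)cc1`, 14000 nM.

Compound 1 gives the lowest number of the three in this assay, but compound 2 lies within the scatter of it (a 1.3-fold higher number from compound 1 to compound 2 (0.10 log units; within the scatter)), and only compound 3 stands clearly higher. Compound 4 `O=S(=O)(NCCCNCc1cccc(Cl)c1)c1cc(C(F)(F)F)cc(C(F)(F)F)c1` has not been measured. It carries 3-chlorophenyl in place of 4-(trifluoromethyl)phenyl on a saturated chain carbon bound to an amine nitrogen. Among the measured compounds shown here, the only single-place step in hand, a 1.3-fold higher number from compound 1 to compound 2 (0.10 log units; within the scatter), also swaps the group on the benzyl ring and left the number unchanged within the scatter; the present swap is a different group at a different place, so that step is a weak guide. No step beyond the scatter is therefore expected in this assay, and compound 4 is estimated at 2500 nM (range 1000 nM to 6500 nM). That expectation means a 1.3-fold higher number from compound 1 to compound 4 (0.10 log units; within the scatter).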

Compound 4, concentration for 50% growth inhibition: 5900 nM
The estimate for compound 4 lay 2.4-fold (0.37 log units) below the measured number; the range from low to high includes it.
By their numbers in this assay, from the lowest: compounds 1 and 2 (each within the scatter of the next); then compound 4; then compound 3.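

In this assay a swap on the benzyl group now moves the number beyond the scatter: 3-chlorophenyl in place of 4-(trifluoromethyl)phenyl gives a 3.0-fold higher number from compound 1 to compound 4 (0.47 log units; beyond the scatter), a modest step, whereas phenyl in place of trifluoromethyl on that ring gave only a 1.3-fold higher number from compound 1 to compound 2 (0.10 log units; within the scatter). So this place on the saturated chain carbon bound to the amine nitrogen does respond to change, though this swap alters both the group and its ring number, and the step cannot separate the two. No measurement shown bears on the reason for this step.

Open, on these data alone, is whether a nitrile or a methoxy group on the benzyl ring would hold the number near that of compound 1. Also open, as far as these compounds go, is how an amide in place of the amine would read.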